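Phenoxy to (Methylcarbamoyl)amino on a Carbonyl Carbon

This account rests on a few compounds, and the source may have more. Where it says the series, first, only, none or still open, it means among the compounds named here.

Of the compounds shown here, three have been measured in a functional assay on blood (Homo sapiens), with a stated time of 60 min, in the presence of a further agent that is not named here; a higher number here means that more compound is needed for the effect, a lower number that less compound is needed.
Compound 1 `O=C(Oc1ccccc1)C1(S(=O)(=O)c2ccc(Oc3ccc(OC(F)(F)F)cc3)cc2)CCC2(CCNCC2)C1` gives 900 nM.
Compound 2 `CNC(=O)NC(=O)C1(S(=O)(=O)c2ccc(Oc3ccc(OC(F)(F)F)cc3)cc2)CCC2(CCNCC2)C1` gives only the limit < 400 nM.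
Compound 3 `COc1ccc(S(=O)(=O)C2(C(=O)Oc3ccccc3)CCC3(CCNCC3)C2)cc1Cl` gives 3700 nM.

Compound 3 holds the highest of the two numbers, and compound 1 is its nearest neighbour; the difference between the two cores is not broken down here. From compound 1 to compound 2 the change is (methylcarbamoyl)amino in place of phenoxy on a carbonyl carbon, and it brought an at least 2.2-fold lower number from compound 1 to compound 2 (0.35 log units; beyond the scatter). The value of compound 2 is a limit of this assay, as recorded in the limit of < 400 nM in this assay, at which 1 of the 3 values shown sits.

Compound 4 `CNC(=O)NC(=O)C1(S(=O)(=O)c2ccc(OC)c(Cl)c2)CCC2(CCNCC2)C1` has not yet been measured. It differs from compound 3 by the same change, ((methylcarbamoyl)amino in place of phenoxy on a carbonyl carbon). Resting on an at least 2.2-fold lower number from compound 1 to compound 2 (0.35 log units; beyond the scatter), compound 4 is expected to show a 2.8-fold lower number from compound 3 to compound 4 (0.45 log units; beyond the scatter) in this assay. Compound 4 is therefore estimated at 1300 nM, within a range from 500 nM to 3000 nM.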

Compound 4, half-maximal effective concentration: > 15000 nM
Compound 4 was reported as a limit (the forecaster's own chance of this, stated with the estimate: 10%); at least 11-fold (1.06 log units) between middle value and limit.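

In this assay compound 4 is recorded only as a limit, > 15000 nM. On the core of compound 3, (methylcarbamoyl)amino in place of phenoxy on a carbonyl carbon brought an at least 4.0-fold higher number from compound 3 to compound 4 (0.60 log units; beyond the scatter), so the step seen on the core of compound 1 did not carry over: the same change on two cores in this assay, an at least 2.2-fold lower number (0.35 log units; beyond the scatter) from compound 1 to compound 2 and an at least 4.0-fold higher number (0.60 log units; beyond the scatter) from compound 3 to compound 4, at least 9.1-fold (0.96 log units) apart, beyond the scatter of two such steps. This shows that in these two pairs the outcome of the change depends on the core, but it does not show which part of the cores decides this, and both steps rest on limits.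

The compounds shown leave open how an amino or a hydroxyl group in place of phenoxy would read in this assay. They also leave open whether a core carrying methoxy without chlorine would follow compound 1 or compound 3.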